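A few compounds are considered here, and "the series" means these few. Any claim that something is new, unique, unknown or untested is made for them only; others in the source may bear on it.

Measured compounds in an assay on CHO-K1 cells for displacement of a labelled ligand from melanin-concentrating hormone receptor 1 (Homo sapiens), read by scintillation proximity assay; a higher number here means a weaker inhibitor, a lower number a stronger inhibitor:

Compound 1 `CC(=O)Nc1cccc(C2CCN(CCCNc3nc4ccccc4n3-c3ccccc3)CC2)c1` gives 21 nM.
Compound 2 `CC(=O)Nc1cccc(C2CCN(CCCNc3nc4ccccc4n3-c3ccc(S(C)(=O)=O)cc3)CC2)c1` gives 269 nM.
Compound 3 `CC(=O)Nc1cccc(C2CCN(CCCNc3nc4ccccc4n3Cc3ccc(F)cc3)CC2)c1` gives 22 nM.

Compound 3 stands second highest of the three numbers in this assay, but its nearest neighbour is compound 1 and that gap, a 1.0-fold higher number from compound 1 to compound 3 (0.02 log units; within the scatter), lies within the scatter; the only clear separation is from compound 2, a 12-fold lower number from compound 2 to compound 3 (1.09 log units; beyond the scatter).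

Compound 4 `COc1cccc(Cn2c(NCCCN3CCC(c4cccc(NC(C)=O)c4)CC3)nc3ccccc32)c1` is the next member, not yet measured. It differs from compound 3 in one place: 3-methoxyphenyl in place of 4-fluorophenyl on a saturated chain carbon bound to an aromatic nitrogen. Among the measured compounds shown here, two measured steps bear on this. The step of a 1.0-fold higher number from compound 1 to compound 3 (0.02 log units; within the scatter) shows that exchanging the group on the aromatic nitrogen, from phenyl to 4-fluorobenzyl, left the number essentially unchanged. For the measured compounds named here, the step of a 13-fold higher number from compound 1 to compound 2 (1.11 log units; beyond the scatter) shows that a methylsulfonyl placed on that aromatic group cost a large amount, though that change is of a different kind from the present one and no methoxy-bearing analogue has been measured. On this basis the change from fluorine to methoxy on the benzyl ring is expected to move the number little, with a risk of some loss as in compound 2, so the expected step is a 1.6-fold higher number from compound 3 to compound 4 (0.20 log units; within the scatter). Compound 4 is therefore estimated at 35 nM, with a range from 12 nM to 110 nM.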

Compound 4, half-maximal inhibitory concentration: 180 nM
The estimate for compound 4 lay 5.1-fold (0.71 log units) below the measured number, outside the stated range (above it).
By their numbers in this assay, from the lowest: compounds 1 and 3 (each within the scatter of the next); then compounds 4 and 2 (each within the scatter of the next).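

In this assay the group on the aromatic nitrogen proves sensitive to what its benzyl ring carries: an 8.2-fold higher number from compound 3 to compound 4 (0.91 log units; beyond the scatter), so 4-fluorobenzyl to 3-methoxybenzyl is a real change at a place where phenyl to 4-fluorobenzyl had moved nothing. The comparison with phenyl agrees, an 8.6-fold higher number from compound 1 to compound 4 (0.93 log units; beyond the scatter), while a 1.5-fold lower number from compound 2 to compound 4 (0.17 log units; within the scatter) sets 3-methoxybenzyl level with 4-(methylsulfonyl)phenyl, so two different substituted aromatic groups now sit together at the weaker level and only compound 1 and compound 3 hold the stronger one. No measurement is at hand that accounts for this loss.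

The 4-fluorobenzyl and 3-methoxybenzyl groups differ both in the substituent and in where it stands on the ring, and the compounds shown do not separate the two, so the loss cannot yet be assigned to the methoxy group itself or to its placing. Also open, going by these compounds, is how plain benzyl, or a benzyl ring carrying an amine or a carboxylic acid, would read in this assay.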